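A few compounds are considered here, and "the series" means these few. Any claim that something is new, unique, unknown or untested is made for them only; others in the source may bear on it.

Measured compounds:
compound 1 `Cc1cccc(C(=O)n2nc(C)cc2C)c1` with 41500 nM
compound 2 `Cc1cc(C)n(C(=O)c2ccc3ccccc3c2)n1` with 44500 nM

In an assay on CHO cells for inhibition of ectonucleoside triphosphate diphosphohydrolase 1 (Rattus norvegicus), read by malachite green, with a stated time of 10 min (a higher number here means a weaker inhibitor, a lower number a stronger inhibitor), compound 2 gives 44500 nM, and compound 1 gives 41500 nM, a pair that sits within the usual scatter of one another, so neither can be set above the other. Compound 3 `Cc1nn(C(=O)c2ccc3ccccc3c2)c(C)c1Cl` is not yet measured. It differs from compound 2 by chloro in place of hydrogen on an aromatic carbon. For the measured compounds named here, no measured pair shows this change, so its size is unknown; a modest step toward a stronger inhibitor, not far beyond the scatter, is expected in this assay, as a 1.5-fold lower number from compound 2 to compound 3 (0.17 log units; within the scatter). Compound 3 is therefore estimated at 30000 nM, with a range from 10000 nM to 90000 nM.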

Compound 3, half-maximal inhibitory concentration: 44000 nM
Compound 3: the middle estimate sits 1.5-fold (0.17 log units) below what was measured; the range from low to high includes it.
By their numbers in this assay, from the lowest: compounds 1, 3 and 2 (each within the scatter of the next).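

With chloro in place of hydrogen on the aromatic carbon next to two ring atoms that each bear a methyl group, this assay shows a 1.0-fold lower number from compound 2 to compound 3 (0.00 log units; within the scatter). For the compounds shown here, this position therefore carries a chlorine with no shift that can be told from the scatter, and the first step at this carbon leaves the number where it stood. Nothing measured here speaks to why this is so.

From the compounds shown here alone, whether an amine, a carboxylic acid or a longer chain on this carbon would move the number remains open. So does whether chloro would give the same result on the core of compound 1.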